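Dithiocarbamate series: restoring the pyridinylmethyl amine on compound 2

The source may hold more compounds than are shown below. What is called first, only, known or untested is meant among the compounds shown, and "the series" means these compounds.

Measured compounds:
compound 1 `CCN(Cc1ccncc1)C(=S)SCc1ccc(C(=O)Nc2ccccc2N)cc1` — 71.6%
compound 2 `CC1CCN(C(=S)SCc2ccc(C(=O)Nc3ccccc3N)cc2)CC1` — 28.1%

In a functional assay on MGC-803 cells (Homo sapiens) for antiproliferative activity, read by CCK-8 assay, with a stated time of 72 h, tested at 2 uM (a lower number here means a weaker effect, a higher number a stronger effect of the compound at the concentration tested), compound 1 gives 71.6%, whereas compound 2 gives 28.1%. Compound 2 therefore stands lowest of the two numbers, and the step of a number 43.5 percentage points lower from compound 1 to compound 2 (beyond the scatter) is beyond the scatter.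

Compound 3 `CN(Cc1ccncc1)C(=S)SCc1ccc(C(=O)Nc2ccccc2N)cc1` is not yet measured. Its difference from compound 2 is methyl((pyridin-4-yl)methyl)amino in place of 4-methylpiperidin-1-yl on a thiocarbonyl carbon.

Among the compounds with values here, only one measured step bears on this change, and it runs the other way: a number 43.5 percentage points lower from compound 1 to compound 2 (beyond the scatter) took the series from an ethyl((pyridin-4-yl)methyl)amino group to the 4-methylpiperidin-1-yl group, with a large loss. Compound 3 brings back a close relative of the group that compound 1 carried, with methyl in place of ethyl on the amino nitrogen. A rise beyond the scatter is expected, of a size near that earlier loss, because a number 43.5 percentage points lower from compound 1 to compound 2 (beyond the scatter) was large. Whether the methyl for ethyl exchange matters cannot be judged from these two compounds alone.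

Compound 3 is therefore estimated at 65%, within a range from 45% to 82%. This estimate means an expected step of a number 36.9 percentage points higher from compound 2 to compound 3 (beyond the scatter).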

Compound 3, a percentage reported as inhibition, at one concentration (the size of the read-out at that concentration, not a potency): 38.1%
The estimate for compound 3 lay 26.9 percentage points above the measured number, and the stated range ends above it.
By their numbers in this assay, from the lowest: compounds 2 and 3 (each within the scatter of the next); then compound 1.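

In this assay, the result separates two things that compound 1 and compound 2 could not: the ((pyridin-4-yl)methyl)amino part and the chain on the same nitrogen. With methyl on that nitrogen, the methyl((pyridin-4-yl)methyl)amino group is not told apart from 4-methylpiperidin-1-yl on the thiocarbonyl carbon, giving a number 10 percentage points higher from compound 2 to compound 3 (within the scatter), so the pyridinylmethyl part alone does not restore the read-out of compound 1. The one-place change of hydrogen in place of methyl on a saturated chain carbon bound to an amide-type nitrogen gives a number 33.5 percentage points lower from compound 1 to compound 3 (beyond the scatter), which shows that this small edit to the ethyl chain is enough for a large step, and nothing available explains why.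

The compounds shown leave open whether a propyl or butyl chain on that nitrogen would extend the step seen between methyl and ethyl, or whether ethyl is a narrow optimum. They also leave open whether ethyl would keep its effect with a benzyl group in place of the pyridin-4-ylmethyl group.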